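The source may hold more compounds than are shown below. What is called first, only, known or untested is meant among the compounds shown, and "the series" means these compounds.

Compounds measured so far:
compound 1 `COc1cc(C2OC(c3ccc(N)c(C)c3)=NN2C(C)=O)cc(OC)c1OC`, 0.059 uM
compound 2 `COc1cc(C2OC(c3ccc(N(C)C)cc3)=NN2C(C)=O)cc(OC)c1OC`, 0.044 uM
compound 3 `COc1cc(C2OC(c3ccccc3N(C)C)=NN2C(C)=O)cc(OC)c1OC`, 109 uM

In a functional assay on NCI-H460 cells (Homo sapiens) (on this read-out higher numbers stand for an effect only at larger amounts of compound and lower numbers for an effect already at smaller amounts), compound 2 gives the lowest of the three numbers; compound 1 lies within the scatter of it, as the step of a 1.3-fold lower number from compound 1 to compound 2 (0.13 log units; within the scatter) shows, while compound 3 is far removed, as the step of a 2500-fold higher number from compound 2 to compound 3 (3.39 log units; beyond the scatter) shows, with the step of a 1800-fold higher number from compound 1 to compound 3 (3.27 log units; beyond the scatter) of like size. All three measured steps concern the aryl group on the carbon with a double bond to nitrogen. Compound 4 `COC(=O)N1N=C(c2ccc(N(C)C)cc2)OC1c1cc(OC)c(OC)c(OC)c1` keeps that aryl group of compound 2 and differs elsewhere: methoxy in place of methyl on a carbonyl carbon. Within the data shown here, no measured step bears on this change, so an estimate must rest on compound 2 alone, and a step of a 1.1-fold higher number from compound 2 to compound 4 (0.06 log units; within the scatter), within the scatter, is expected. Compound 4 is therefore estimated at 0.05 uM, between 0.015 uM and 0.2 uM.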

Compound 4, concentration for half-maximal effect: 106 uM
Estimate against measurement, compound 4: 2100-fold (3.33 log units) below; measured number above the stated range.
By their numbers in this assay, from the lowest: compounds 2 and 1 (each within the scatter of the next); then compounds 4 and 3 (each within the scatter of the next).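

Methoxy in place of methyl on a carbonyl carbon is not a silent change in this assay: it gives a 2400-fold higher number from compound 2 to compound 4 (3.38 log units; beyond the scatter), although the aryl group of compound 2 stays in place. The earlier compounds shown here showed a step of this size only at the aryl group, so the acetyl group, whose carbonyl carbon bears the amide-type nitrogen in a ring, matters as well. No measurement shown here explains this step.

From the compounds shown here alone, it remains open whether any replacement of the methyl is tolerated, for instance an ethyl or a dimethylamino group on that carbonyl carbon. Going by these compounds, it is also open whether acetyl to methoxycarbonyl costs as much with the 4-amino-3-methylphenyl group of compound 1.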